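Shortening the acyl chain on the shared core

The source may hold more compounds than are shown below. What is called first, only, known or untested is meant among the compounds shown, and "the series" means these compounds.

Measured compounds in a toxicity assay on KB cells (Homo sapiens) for cytotoxicity, read by fluorescence, with a stated time of 3 days; on this read-out lower numbers stand for an effect already at smaller amounts and higher numbers for an effect only at larger amounts of compound:
compound 1, `CCCCOC(=O)CNC(=O)[C@H](CSc1ccc([N+](=O)[O-])cc1[N+](=O)[O-])NC(=O)CC[C@H](NC(=O)CC(C)C)C(=O)OCCCC`: 59.6 uM
compound 2, `CCCCOC(=O)CNC(=O)[C@H](CSc1ccc([N+](=O)[O-])cc1[N+](=O)[O-])NC(=O)CC[C@H](NC(=O)CCc1ccccc1)C(=O)OCCCC`: > 300 uM
compound 3, `CCCCOC(=O)CNC(=O)[C@H](CSc1ccc([N+](=O)[O-])cc1[N+](=O)[O-])NC(=O)CC[C@H](NC(=O)OCc1ccccc1)C(=O)OCCCC`: 95.2 uM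

Compound 1 gives the lowest of the two numbers shown, with compound 3 nearest. The value of compound 2 is a limit of the assay, not a number. It stands at the limit of > 300 uM in this assay, at which 1 of the 3 values shown sits. In this series, the acyl group attached to the amide-type nitrogen of the shared core is varied while everything else stays the same.

Compound 4, `CCCCOC(=O)CNC(=O)[C@H](CSc1ccc([N+](=O)[O-])cc1[N+](=O)[O-])NC(=O)CC[C@H](NC(=O)C(C)C)C(=O)OCCCC`, has not yet been measured. It differs from compound 1 by isopropyl in place of isobutyl on a carbonyl carbon.

Within the data shown here, two measured steps bear on this change. The step of a 1.6-fold higher number from compound 1 to compound 3 (0.20 log units; within the scatter) exchanges one small group for another on the same carbonyl carbon and stays within the scatter. The step of an at least 5.0-fold higher number from compound 1 to compound 2 (0.70 log units; beyond the scatter) brings in a larger aromatic group and goes beyond the scatter. Removing one carbon, as in compound 4, is a smaller change than either, so a step from compound 1 that stays within the scatter is expected in this assay, with no clear direction.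

Compound 4 is therefore expected to give about 70 uM in this assay, between 35 uM and 150 uM, which means an expected step of a 1.2-fold higher number from compound 1 to compound 4 (0.07 log units; within the scatter).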

Compound 4, concentration for half-maximal effect: > 300 uM
Compound 4 gave a limit, no number; the forecaster's own chance of this, stated with the estimate: 10%; middle value at least 4.2-fold (0.63 log units) from the limit.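

In this assay, among these compounds, the removal of a single carbon, isobutyl to isopropyl on the carbonyl carbon, gives an at least 5.0-fold higher number from compound 1 to compound 4 (0.70 log units; beyond the scatter), so even a small change at this position can carry a step beyond the scatter, which the earlier compounds did not show. Compound 3, with its larger benzyloxy group, also lies apart from the new compound, with an at least 3.1-fold higher number from compound 3 to compound 4 (0.49 log units; beyond the scatter), so among these four compounds a larger group does not simply go with a higher number: the small isopropyl and the large phenethyl both reach the limit, while isobutyl and benzyloxy do not. The value of compound 4 is a limit, as is that of compound 2, so the step between these two cannot be read: the limit of > 300 uM in this assay, at which 2 of the 4 values shown sit.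

As far as these compounds go, it remains open how far compound 2 and compound 4 lie beyond that limit, and so whether they truly differ from each other. From the compounds shown here alone, it is also open whether a straight butyl chain or a longer chain on the same carbonyl carbon would stay close to compound 1 or reach the limit too, and what an amine or a carboxylic acid on this acyl group would do.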